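This account rests on a few compounds, and the source may have more. Where it says the series, first, only, none or still open, it means among the compounds named here.

Measured compounds in a physicochemical assay for lipophilicity, read by LC-MS, in phosphate buffer, measured as octanol-water partition, with a stated time of 30 min, at pH 7.4, tested at 200 mM; on this read-out lower numbers stand for lower lipophilicity and higher numbers for higher lipophilicity:
compound 1 `Cc1ccc(Oc2ccc3nc(COc4cccc(C(=O)O)c4)n(C)c3n2)c(C)c1` gives 2.3
compound 2 `Cc1cc(C)cc(Oc2ccc3nc(COc4cccc(C(=O)O)c4)n(C)c3n2)c1` gives 2.3
compound 3 `Cc1ccc(Oc2ccc3nc(COc4cccc(C(=O)O)c4)n(C)c3c2)nc1` gives 0.9

Compound 3 stands lowest of the three numbers in this assay. Compound 1 and compound 2 sit well above it, beyond the scatter, and are within the scatter of each other. Among the compounds with values here, the only single-place step measured so far is no change at the digits printed from compound 1 to compound 2 (within the scatter); it exchanges one dimethylphenyl for another on the oxygen and shows nothing beyond the scatter. Within the data shown here, compound 3 differs from compounds 1 and 2 in more than one place, so no single step is recorded for that pair; the two values merely show that compound 3 is the lower one.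

Compound 4 `Cc1cc(Cl)cnc1Oc1ccc2nc(COc3cccc(C(=O)O)c3)n(C)c2c1` is not yet measured in this assay. It differs from compound 3 by 5-chloro-3-methylpyridin-2-yl in place of 5-methylpyridin-2-yl on an oxygen on an aromatic ring. Among the measured compounds shown here, no measured step adds a chlorine or a second ring substituent, so nothing recorded bears directly on this change. The step from compound 1 to compound 2 only shows that moving methyl groups around a ring leaves the value unchanged.

In the absence of a matching step, a moderate rise is expected for compound 4, with a number 0.60 log units higher from compound 3 to compound 4 (beyond the scatter) as the estimated step. Compound 4 is estimated at 1.5, within 1 to 2.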

Compound 4, distribution coefficient: 1.8
Beside the measured number, compound 4's estimate is 0.30 log units below it, within the range that was stated.
By their numbers in this assay, from the lowest: compound 3; then compound 4; then compounds 1 and 2 (each within the scatter of the next).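

In this assay, within the data shown here, 5-chloro-3-methylpyridin-2-yl in place of 5-methylpyridin-2-yl on an oxygen on an aromatic ring gives a number 0.90 log units higher from compound 3 to compound 4 (beyond the scatter), the first step at this place that lies beyond the scatter, whereas the exchange of one dimethylphenyl for another gave no change at the digits printed from compound 1 to compound 2 (within the scatter). The number at this place therefore responds to the group it carries, at least when the pyridine ring gains substituents and not merely when methyl groups are rearranged on a phenyl ring. No measurement here accounts for the size of the step, and the entering group brings a chlorine and a further methyl at once, so the step belongs to the pair and cannot be divided between them.

The compounds shown leave open how much of the step goes with the chlorine and how much with the added methyl, since no ring carrying only one of the two appears among them. They also leave open whether an amine, a methoxy group or a longer alkyl chain in place of the chlorine would give a step of similar size in this assay.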